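Chloro to methyl in a small cytotoxicity series

This account rests on a few compounds, and the source may have more. Where it says the series, first, only, none or still open, it means among the compounds named here.

Measured in a functional assay on HL-60 cells (Homo sapiens) for cytotoxicity, with a stated time of 24 h; on this read-out higher numbers stand for lower toxicity in this test and lower numbers for higher toxicity in this test
- compound 1 `O=C1/C(=C/c2ccc(F)cc2)CCC/C1=C\c1ccccc1[N+](=O)[O-]` gives 3000 nM
- compound 2 `O=C1/C(=C/c2ccccc2)CCC/C1=C\c1ccc([N+](=O)[O-])cc1` gives 20000 nM
- compound 3 `O=C1/C(=C/c2ccc(Cl)cc2)CCC/C1=C\c1ccc([N+](=O)[O-])cc1` gives 4100 nM

Compound 3 lies within the scatter of compound 1 and beyond the scatter from compound 2, which has the higher number. Compound 4 `Cc1ccc(/C=C2\CCC/C(=C\c3ccc([N+](=O)[O-])cc3)C2=O)cc1` differs from compound 3 by methyl in place of chloro on an aromatic carbon, with methyl in place of chloro on an aromatic carbon. Within the data shown here, one measured step bears on this: a 4.9-fold lower number from compound 2 to compound 3 (0.69 log units; beyond the scatter), with chloro in place of hydrogen. Among the measured compounds shown here, no methyl compound has been measured. Methyl may recover only part of that step, so a modest rise is expected in this assay. The expected step is a 1.8-fold higher number from compound 3 to compound 4 (0.26 log units; within the scatter). Compound 4 is estimated at 7500 nM, within 2800 nM to 20000 nM.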

Compound 4, half-maximal cytotoxic concentration: 27000 nM
Compound 4: middle estimate off by 3.6-fold (0.56 log units), on the low side, outside the stated range (above it).
By their numbers in this assay, from the lowest: compounds 1 and 3 (each within the scatter of the next); then compounds 2 and 4 (each within the scatter of the next).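

In this assay the change from 4-chlorophenyl to 4-methylphenyl gives a clear rise (a 6.6-fold higher number from compound 3 to compound 4 (0.82 log units; beyond the scatter)), so methyl does not share the drop seen with chloro at this position. Methyl in place of hydrogen stays within the scatter (a 1.4-fold higher number from compound 2 to compound 4 (0.13 log units; within the scatter)), which leaves chloro as the only one of these three groups that lowers the number here. Nothing available accounts for this difference between chloro and methyl. As far as these compounds go, whether the lower number is specific to chloro remains open, as a bromo, methoxy or amino group at this position would show. From the compounds shown here alone, whether methyl behaves the same way with the nitro group placed elsewhere on the other ring also remains open.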